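Acyl aromatic exchanges on the shared core: compound 4

The source may hold more compounds than are shown below. What is called first, only, known or untested is meant among the compounds shown, and "the series" means these compounds.

Working notes on the series. Compound 1 `COc1cc2nc(N3CCN(C(=O)c4ccc(Br)o4)[C@H]4CCCC[C@H]43)nc(N)c2cc1OC` gives 0.309 nM in an assay on CHO cells for displacement of a labelled ligand from Alpha-1B adrenergic receptor (Homo sapiens); a higher number here means a weaker inhibitor, a lower number a stronger inhibitor; compound 2 `COc1cc2nc(N3CCN(C(=O)c4ccc(C(C)=O)o4)[C@H]4CCCC[C@H]43)nc(N)c2cc1OC` gives 1.38 nM, and compound 3 `COc1cc2nc(N3CCN(C(=O)c4ccccn4)[C@H]4CCCC[C@H]43)nc(N)c2cc1OC` gives 5.89 nM, the highest of the three numbers. The step to compound 4 `COc1cc2nc(N3CCN(C(=O)c4ccccc4)[C@H]4CCCC[C@H]43)nc(N)c2cc1OC` is phenyl in place of pyridin-2-yl on a carbonyl carbon. Among the compounds with values here, no measured pair makes this exact exchange; the nearest are the two replacements of the aromatic group on the carbonyl carbon, a 19-fold higher number from compound 1 to compound 3 (1.28 log units; beyond the scatter) and a 4.3-fold higher number from compound 2 to compound 3 (0.63 log units; beyond the scatter), both beyond the scatter. Both of those brought in pyridin-2-yl; replacing it with phenyl, a ring of carbon only, is a different exchange, so the expected step of a 2.0-fold lower number from compound 3 to compound 4 (0.29 log units; within the scatter) is small and not clearly beyond the scatter, if anything toward a lower number. Compound 4 is estimated at 3 nM, within 1 nM to 10 nM.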

Compound 4, inhibition constant: 0.49 nM
Compound 4: the middle estimate sits 6.1-fold (0.79 log units) above what was measured; measured number outside the range, below it.
By their numbers in this assay, from the lowest: compounds 1 and 4 (each within the scatter of the next); then compound 2; then compound 3.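

Swapping pyridin-2-yl for phenyl on this carbonyl carbon gives a 12-fold lower number from compound 3 to compound 4 (1.08 log units; beyond the scatter), so one ring nitrogen in an otherwise matched six-membered aromatic ring separates these two compounds. The unsubstituted phenyl also gives a 2.8-fold lower number from compound 2 to compound 4 (0.45 log units; beyond the scatter) and a 1.6-fold higher number from compound 1 to compound 4 (0.20 log units; within the scatter), the latter within the scatter, so a substituted furan is not required for a low number. No available evidence bears on the size of the nitrogen-to-carbon step.

Open, on these data alone, is whether pyridin-3-yl behaves like pyridin-2-yl or like phenyl, and whether a methoxy group or an amine on the phenyl ring keeps the number low.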